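A Fluoro Substituent Added to the Amide-Bearing Ring

The source may hold more compounds than are shown below. What is called first, only, known or untested is meant among the compounds shown, and "the series" means these compounds.

Among the compounds with values here, in a functional assay on A549 cells (Homo sapiens) for cytotoxicity, read by MTT assay, with a stated time of 72 h (a higher number here means a weaker inhibitor, a lower number a stronger inhibitor), compound 2 `Cc1cc(=O)n(-c2cccc(C(F)(F)F)c2)nc1C(=O)Nc1ccc(Oc2ncnc3[nH]ccc23)cc1` gives 7570 nM, the highest of the two numbers so far measured. Compound 1 `Cc1cc(=O)n(-c2ccc(Br)cc2F)nc1C(=O)Nc1ccc(Oc2ncnc3[nH]ccc23)cc1` gives 3770 nM in this assay, and the step of a 2.0-fold higher number from compound 1 to compound 2 (0.30 log units; within the scatter) concerns only the group on the aromatic nitrogen. Compound 3 `Cc1cc(=O)n(-c2cccc(C(F)(F)F)c2)nc1C(=O)Nc1ccc(Oc2ncnc3[nH]ccc23)c(F)c1` differs from compound 2 by fluoro in place of hydrogen on an aromatic carbon. Within the data shown here, no measured step touches this change, and the single known step of a 2.0-fold higher number from compound 1 to compound 2 (0.30 log units; within the scatter) lies within the scatter. Compound 3 is therefore expected to show a step of a 1.1-fold lower number from compound 2 to compound 3 (0.03 log units; within the scatter), nothing beyond the scatter. Compound 3 is estimated at 7000 nM, between 2500 nM and 20000 nM.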

Compound 3, half-maximal inhibitory concentration: 35100 nM
Estimate against measurement, compound 3: 5.0-fold (0.70 log units) below, and the stated range ends below it.
By their numbers in this assay, from the lowest: compounds 1 and 2 (each within the scatter of the next); then compound 3.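

The step of a 4.6-fold higher number from compound 2 to compound 3 (0.67 log units; beyond the scatter) in this assay shows that this aromatic carbon, ortho to a large group and meta to a large group, does not tolerate every change: a single fluoro in place of hydrogen gives a weaker inhibitor. Within the data shown here, this is the first step to lie beyond the scatter, and it involves only one heavy atom. Nothing available bears on the reason for this shift. On these data alone, whether a chloro, a methoxy or an amine on the same carbon would act likewise stays open. So does whether fluoro has the same effect with the group on the aromatic nitrogen of compound 1.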